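Methoxy in place of hydrogen on compound 2

The source may report more compounds than this note shows. Statements on the series, on what has been measured and on what is new or still open speak of the compounds shown alone.

Of the compounds shown here, three have numbers so far in an ADME assay on HepG2 cells (Homo sapiens) for cytotoxicity, read by CellTiter-Glo, with a stated time of 48 h (on this read-out higher numbers stand for lower toxicity in this test and lower numbers for higher toxicity in this test), and they do not separate. Compound 2 (`CCCCNc1nc2ccccc2nc1S(C)(=O)=O`) gives 12600 nM in this series, and compound 3 (`COc1ccc2nc(NC3CCCCC3)c(S(C)(=O)=O)nc2c1`) gives 12600 nM at the same digits. Compound 1 (`CCCCNc1nc2ccc(OC)cc2nc1S(C)(=O)=O`) gives 20000 nM and stays within the scatter of both. Compound 2 therefore stands level with compound 3 and within the scatter of compound 1.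

Compound 4 (`CCCCNc1nc2cc(OC)ccc2nc1S(C)(=O)=O`) differs from compound 2 by methoxy in place of hydrogen on an aromatic carbon. The measured step closest to this change is a 1.6-fold lower number from compound 1 to compound 2 (0.20 log units; within the scatter) for hydrogen in place of methoxy, which is the same kind of change read in reverse. However, compound 1 and compound 3 carry their methoxy on a different aromatic carbon from compound 4, so this placement has no measured precedent. The other step, a 1.6-fold lower number from compound 1 to compound 3 (0.20 log units; within the scatter) for cyclohexyl in place of butyl on a nitrogen, concerns a different part of the structure and gives only a general sense of how little the numbers have moved.

In this assay no step beyond the scatter is therefore expected. The expected step is a 1.3-fold higher number from compound 2 to compound 4 (0.10 log units; within the scatter) on this estimate. For compound 4 the estimated value is 16000 nM with an expected range of 8000 nM to 30000 nM here.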

Compound 4, half-maximal cytotoxic concentration: > 100000 nM
Compound 4: only a limit was reported (the forecaster's own chance of this, stated with the estimate: 10%); middle value at least 6.2-fold (0.79 log units) from the limit.
By their numbers in this assay, from the lowest: compounds 2, 3 and 1 (each within the scatter of the next). At a limit, above all of these: compound 4.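

In this assay the change of methoxy in place of hydrogen gives an at least 7.9-fold higher number from compound 2 to compound 4 (0.89 log units; beyond the scatter), the first step among these compounds beyond the scatter, and the value of compound 4 behind it is a limit and not a number. Compound 1 carries its methoxy on a different aromatic carbon from compound 4, and there the same change, read in reverse, does not separate the compounds: a 1.6-fold lower number from compound 1 to compound 2 (0.20 log units; within the scatter). Among these compounds, then, the outcome depends on which aromatic carbon carries the methoxy and not on the presence of the group alone, and the reading at this position, meta to a fused ring and para to a fused ring, rests on a limit: the limit of > 100000 nM in this assay, at which 1 of the 4 values shown sits.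

From the compounds shown here alone, the true size of the step stays open, as does whether it belongs to methoxy or to any substituent at this position. Going by these compounds, it is also open whether an amine, a carboxylic acid or a longer chain on this aromatic carbon gives the same separation, and whether it survives cyclohexyl in place of butyl on the nitrogen.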